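This account rests on a few compounds, and the source may have more. Where it says the series, first, only, none or still open, it means among the compounds named here.

Working notes on the series. In a functional assay on MDA-MB-231 cells (Homo sapiens) for antiproliferative activity, read by MTT assay, with a stated time of 72 h (a higher number here means a weaker inhibitor, a lower number a stronger inhibitor), compound 1 (`COc1ccc(-n2ccnc2-c2cc(OC)c(OC)c(OC)c2)cc1[N+](=O)[O-]`) gives 7500 nM, level with compound 2 (`COc1cc(-c2nccn2-c2ccc3cc[nH]c3c2)cc(OC)c1OC`) at 7500 nM. Compound 3 (`COc1cc(-c2nccn2-c2cccc([N+](=O)[O-])c2)cc(OC)c1OC`) reads > 100000 nM, which is a limit of the assay and not a number.

Compound 4 (`COc1ccc(-n2ccnc2-c2cc(OC)c(OC)c(OC)c2)cc1N`) carries amino in place of nitro on an aromatic carbon, ortho to a methoxy group: amino in place of nitro on an aromatic carbon. Within the data shown here, no measured step exchanges the nitro itself. The closest evidence is an at least 13-fold higher number from compound 1 to compound 3 (1.12 log units; beyond the scatter), a large step with hydrogen in place of methoxy, so substitution on this ring can move the number a long way in this assay. Compound 2, at 7500 nM, holds this level with no nitro present, so the nitro does not appear necessary for it. A step beyond the scatter is therefore expected, leaning toward a stronger inhibitor, though its size is poorly constrained. The expected step is a 5.0-fold lower number from compound 1 to compound 4 (0.70 log units; beyond the scatter). Compound 4 is estimated at 1500 nM, with an expected range of 100 nM to 20000 nM.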

Compound 4, half-maximal inhibitory concentration: 1040 nM
Compound 4: the middle estimate sits 1.4-fold (0.16 log units) above what was measured, and the stated range covers the measured number.
By their numbers in this assay, from the lowest: compound 4; then compounds 1 and 2 (each within the scatter of the next). At a limit, above all of these: compound 3.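

Among these compounds, this is the first measured exchange of the nitro itself: in this assay the change reads a 7.2-fold lower number from compound 1 to compound 4 (0.86 log units; beyond the scatter) and runs toward a stronger inhibitor. Nitro is therefore not required at this position, ortho to a methoxy group, and the number there responds to the group carried on that carbon, not only to substitution elsewhere on the ring. Compound 3 stands at a limit and not a number, so the step with hydrogen in place of methoxy gives no size to set against this one: the limit of > 100000 nM in this assay, at which 1 of the 4 values shown sits.

The compounds shown leave open whether the gain belongs to amino itself or to the loss of nitro, which a hydroxyl or an acetamide on the same carbon would help separate. As far as these compounds go, the methoxy step is also read only with nitro present, so its weight alongside amino remains unknown.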